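The source may report more compounds than this note shows. Statements on the series, on what has been measured and on what is new or still open speak of the compounds shown alone.

Three compounds were measured in an assay on membranes from HeLa cells for displacement of a labelled ligand from adenosine receptor A3 (Homo sapiens), read by scintillation counting, with a stated time of 180 min, tested at 1 uM; on this read-out higher numbers stand for more inhibition at the one concentration tested (going by the name of the read-out) and lower numbers for less inhibition: compound 1 `CCOC(=O)C1=C(C)N(C)C(=O)NC1c1cccs1`, compound 2 `CCCOC(=O)C1=C(C)N(C)C(=O)NC1c1cccs1` and compound 3 `CCCC(=O)C1=C(C)NC(=O)NC1c1ccsc1`. In this assay compound 1 gives 2%, and compound 2 gives 4%. The change between them is methyl in place of hydrogen on a saturated chain carbon, two bonds along the chain from an oxygen next to a carbonyl group, and in this assay it made a step of a number 2 percentage points higher from compound 1 to compound 2 (within the scatter). Compound 3, built on a different core, gives 1% in this assay; the difference between its core and the core of compound 1 is not broken down here, and its value sits within the scatter of both compound 1 and compound 2.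

Compound 4 `CC1=C(C(=O)CC(C)C)C(c2ccsc2)NC(=O)N1` is not yet measured. It differs from compound 3 by methyl in place of hydrogen on a saturated chain carbon bound to two saturated chain carbons. This is the same kind of change as that from compound 1 to compound 2, but not the same: there the place was on a saturated chain carbon, two bonds along the chain from an oxygen next to a carbonyl group, whereas here it is on a saturated chain carbon bound to two saturated chain carbons. Because compound 3 gives 1% and the earlier step was a number 2 percentage points higher from compound 1 to compound 2 (within the scatter), compound 4 is expected to give about 2%, likely between -6% and 10%, an estimated step of a number 1 percentage points higher from compound 3 to compound 4 (within the scatter).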

Compound 4, a percentage reported as inhibition, at one concentration (the size of the read-out at that concentration, not a potency): 14%
For compound 4 the middle estimate is 12 percentage points below the measured one; measured number above the stated range.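

In this assay, the methyl in place of hydrogen on a saturated chain carbon bound to two saturated chain carbons made a number 13 percentage points higher from compound 3 to compound 4 (beyond the scatter). Set beside the earlier step on the other core, this step cannot be told apart from it: the same change on two cores in this assay, a number 2 percentage points higher (within the scatter) from compound 1 to compound 2 and a number 13 percentage points higher (beyond the scatter) from compound 3 to compound 4, 11 percentage points apart, within the scatter of two such steps So the series gives no sign that the change behaves differently from one core to the other, but it does not show that the step carries over at a fixed size, as each core supplies a single pair and the methyl stands at a different place in each. The read-out also comes from one concentration and gives no potency.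

The compounds shown leave open how a longer chain, or an amine or carboxylic acid on the chain, would read in this assay. They also leave open whether a propylcarbonyl to isobutylcarbonyl change would give a similar step on the core of compound 1.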